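Urea Linker Replacing Cinnamoyl in a Quinoline Series

This account rests on a few compounds, and the source may have more. Where it says the series, first, only, none or still open, it means among the compounds named here.

Measured compounds:
compound 1 `COc1cc(NC(C)CCCNC(=O)/C=C/c2cc(C(F)(F)F)cc(C(F)(F)F)c2)c2ncccc2c1` gives 158000 nM in an ADME assay on L6 cells (Rattus norvegicus) for cytotoxicity, read by resazurin assay, with a stated time of 70 h; on this read-out higher numbers stand for weaker inhibition and lower numbers for stronger inhibition
compound 2 `COc1cc(NC(C)CCCNC(=O)NNC(=O)/C=C/c2ccc(C(F)(F)F)cc2)c2ncccc2c1` gives 28300 nM in this assay

Compound 2 stands at the lower of the two numbers, and its gap to compound 1 lies beyond the scatter. Compound 3 `COc1cc(NC(C)CCCNC(=O)NNC(=O)Nc2cccc(C(F)(F)F)c2)c2ncccc2c1` differs from compound 2 in one place: (3-(trifluoromethyl)phenyl)amino in place of 2-(4-(trifluoromethyl)phenyl)ethenyl on a carbonyl carbon. Among the compounds with values here, no measured pair shows this change, so the size of the step is open. The expected step in this assay is a 1.9-fold higher number from compound 2 to compound 3 (0.29 log units; within the scatter), a modest rise toward weaker inhibition. Compound 3 is estimated at 55000 nM, within 18000 nM to 170000 nM.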

Compound 3, half-maximal inhibitory concentration: 32100 nM
Estimate against measurement, compound 3: 1.7-fold (0.23 log units) above; the range from low to high includes it.
By their numbers in this assay, from the lowest: compounds 2 and 3 (each within the scatter of the next); then compound 1.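

In this assay, (3-(trifluoromethyl)phenyl)amino in place of 2-(4-(trifluoromethyl)phenyl)ethenyl on a carbonyl carbon gives a 1.1-fold higher number from compound 2 to compound 3 (0.05 log units; within the scatter). Within the data shown here, this is the first step here that changes one place only, and it shows that this swap, which removes the double bond outside the aromatic ring and brings in a hydrogen-bond donor, leaves the number within the scatter. No evidence on why the two compounds read alike is available. Open remains whether a carboxylic acid or an amine on the phenyl ring in place of trifluoromethyl would keep the number. Going by these compounds, a longer chain on that carbonyl carbon is equally open.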